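Working notes: hydroxy for hydrogen, compound 2 to compound 3

The source may hold more compounds than are shown below. What is called first, only, known or untested is meant among the compounds shown, and "the series" means these compounds.

Measured so far:
compound 1 `C[C@@H]1O[C@H](n2cc(COP(=O)(O)OP(=O)(O)OC[C@H]3O[C@@H](n4cnc5c(=O)[nH]c(N)nc54)[C@H](O)[C@@H]3O)nn2)[C@@H](O)[C@H](O)[C@@H]1O` — in an assay on isolated protein for inhibition of 4-galactosyl-N-acetylglucosaminide 3-alpha-L-fucosyltransferase 9 (Homo sapiens), read by scintillation counting, with a stated time of 30 min (a lower number here means a stronger inhibitor, a higher number a weaker inhibitor), compound 1 gives 139000 nM
compound 2 `C[C@H]1O[C@@H](n2cc(COP(=O)(O)OP(=O)(O)OC[C@H]3O[C@@H](n4cnc5c(=O)[nH]c(N)nc54)[C@H](O)[C@@H]3O)nn2)[C@H](O)[C@@H](O)[C@H]1O` — in this assay compound 2 gives 134000 nM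

Compound 2 holds the lowest of the two numbers, with compound 1 sitting within the scatter of it, so no order between them can be read. Among the compounds with values here, the only measured step, a 1.0-fold lower number from compound 1 to compound 2 (0.02 log units; within the scatter), concerns drawn configuration alone: the fact that one of compounds 1 and 2 is drawn with a defined configuration and the other without, at the place where they differ. It says nothing about a change of substituent.

Compound 3 `Nc1nc2c(ncn2[C@@H]2O[C@H](COP(=O)(O)OP(=O)(O)OCc3cn([C@@H]4O[C@H](CO)[C@H](O)[C@H](O)[C@H]4O)nn3)[C@@H](O)[C@H]2O)c(=O)[nH]1` has not yet been measured in this assay. It differs from compound 2 by hydroxy in place of hydrogen on a saturated chain carbon bound to a saturated ring carbon. Within the data shown here, no measured step bears on this change; the step from compound 1 to compound 2 leaves every group in place and stayed within the scatter. In the absence of any guiding step, the expectation for compound 3 in this assay is a number somewhat higher than that of compound 2, written as a 2.2-fold higher number from compound 2 to compound 3 (0.35 log units; beyond the scatter), with a wide range on either side. Compound 3 is therefore estimated at 300000 nM, expected to fall between 100000 nM and 1000000 nM.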

Compound 3, half-maximal inhibitory concentration: 247000 nM
Beside the measured number, compound 3's estimate is 1.2-fold (0.08 log units) above it; the measured number falls inside the stated range.
By their numbers in this assay, from the lowest: compounds 2, 1 and 3 (each within the scatter of the next).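

In this assay the series now holds its first change of substituent, and hydroxy in place of hydrogen on a saturated chain carbon bound to a saturated ring carbon, read one bond further out as methyl to hydroxymethyl, stays within the scatter (a 1.8-fold higher number from compound 2 to compound 3 (0.27 log units; within the scatter)). Replacing the whole group on the aromatic nitrogen of compound 1 with that of compound 3 also stays within the scatter (a 1.8-fold higher number from compound 1 to compound 3 (0.25 log units; within the scatter)), so the three compounds cannot be put in order, and this position tolerates hydroxy without a readable change in this assay. Within the data shown here, the only available evidence concerns drawn configuration and gives no explanation for the hydroxy result.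

What the compounds shown leave open is whether any replacement at this place can move the number beyond the scatter, in either direction, since hydrogen and hydroxy are the only two groups compared there. On these data alone, an amine, a carboxylic acid or a longer chain on the same carbon would test this, and the shared core of the series remains unexplored by these three compounds.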